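The source may hold more compounds than are shown below. What is called first, only, known or untested is meant among the compounds shown, and "the series" means these compounds.

Measured so far:
Compound 1 `O=C(Nc1cc(-c2ccccc2)[nH]n1)c1cccnc1Cl` — 7340 nM
Compound 2 `COc1ncccc1C(=O)Nc1cc(-c2ccccc2)[nH]n1` — 9940 nM
Compound 3 `O=C(Nc1cc(-c2ccccc2)[nH]n1)c1ccc(Cl)nc1` — 7850 nM

All three were tested in a functional assay on A-375 cells (Homo sapiens) for antiproliferative activity, read by MTT assay, with a stated time of 48 h; a higher number here means a weaker inhibitor, a lower number a stronger inhibitor. Compound 3 differs from compound 1 in its core: 6-chloropyridin-3-yl in place of 2-chloropyridin-3-yl on a carbonyl carbon. The step is a 1.1-fold higher number from compound 1 to compound 3 (0.03 log units; within the scatter). Compound 2 differs from compound 1 by one change: methoxy in place of chloro on an aromatic carbon. That step is a 1.4-fold higher number from compound 1 to compound 2 (0.13 log units; within the scatter).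

Compound 4 `COc1ccc(C(=O)Nc2cc(-c3ccccc3)[nH]n2)cn1` has not been measured in this assay. Its difference from compound 3 is methoxy in place of chloro on an aromatic carbon. This is the same kind of change as from compound 1 to compound 2, but the place is not identical: there the group sat ortho to a large group, here it sits para to a large group. Compound 4 is expected to show a 1.3-fold higher number from compound 3 to compound 4 (0.13 log units; within the scatter), resting on the step of a 1.4-fold higher number from compound 1 to compound 2 (0.13 log units; within the scatter). Compound 4 is thus estimated at 10500 nM, most likely between 5000 nM and 22000 nM.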

Compound 4, half-maximal inhibitory concentration: 9560 nM
Beside the measured number, compound 4's estimate is 1.1-fold (0.04 log units) above it; low and high end bracket the measured number.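

Methoxy in place of chloro on an aromatic carbon gives a 1.2-fold higher number from compound 3 to compound 4 (0.09 log units; within the scatter) in this assay. The change carries across the two cores without a difference that can be told from the scatter: the same change on two cores in this assay, a 1.4-fold higher number (0.13 log units; within the scatter) from compound 1 to compound 2 and a 1.2-fold higher number (0.09 log units; within the scatter) from compound 3 to compound 4, 1.1-fold (0.05 log units) apart, within the scatter of two such steps. This shows that the change behaves alike in these two pairs, where both steps are within the scatter, but it does not show that methoxy moves the number at all, and two pairs set no rule for other cores in the series.

The compounds shown leave open whether an amine, a carboxylic acid or a longer alkoxy chain at this place would shift the number beyond the scatter.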